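Exchanging the Carbonyl-Bound Group of Compound 1

A few compounds are considered here, and "the series" means these few. Any claim that something is new, unique, unknown or untested is made for them only; others in the source may bear on it.

In an ADME assay on microsomes from liver (Homo sapiens) for metabolic stability, read by LC-MS, with a stated time of 30 min, tested at 1 uM (on this read-out lower numbers stand for a less stable compound and higher numbers for a more stable compound), compound 1 (`O=C(NCc1ccc(S(=O)(=O)c2ccccc2)cc1)c1cc2ccncc2s1`) gives 48% and compound 2 (`O=C(NCc1ccc(S(=O)(=O)c2ccccc2C(F)(F)F)cc1)c1cc2cnccc2[nH]1`) gives 52% so the two lie within the scatter of each other. Compound 3 (`O=C(NCc1ccc(S(=O)(=O)c2ccccc2)cc1)c1cn2ccnc2cn1`) keeps the rest of compound 1 and carries the change a group of 9 heavy atoms (6 carbon, 3 nitrogen; one five-membered aromatic ring with 2 hetero atoms, one six-membered aromatic ring with 2 hetero atoms) in place of a group of 9 heavy atoms (7 carbon, 1 nitrogen, 1 sulfur; one five-membered aromatic ring with 1 hetero atom, one six-membered aromatic ring with 1 hetero atom), on a carbonyl carbon on a carbonyl carbon. For the measured compounds named here, no measured pair of compounds isolates this exchange, so nothing beyond the scatter is expected in this assay and any expected drift is slightly upward. The step of a number 6 percentage points higher from compound 1 to compound 3 (within the scatter) is expected to stay within the scatter. For compound 3 the estimate is 54% with an expected range from 32% to 76% until it is measured.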

Compound 3, percent of the compound remaining: 87%
The estimate for compound 3 lay 33 percentage points below the measured number; the measured number lies above the stated range.
By their numbers in this assay, from the lowest: compounds 1 and 2 (each within the scatter of the next); then compound 3.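

Exchanging only the group on the carbonyl carbon brings a number 39 percentage points higher from compound 1 to compound 3 (beyond the scatter) in this assay, so the read-out responds strongly at this position. The entering group has the same count of 9 heavy atoms as the one that leaves, but carries 3 nitrogen and no sulfur where the other carried 1 nitrogen and 1 sulfur. No measurement at hand says why the read-out moved.

Which of the exchanged ring atoms carries the step remains open. So does how a single ring on the same carbonyl carbon, such as a pyridine or a thiazole, would stand.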